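Removing a ring methyl from a tocopherol-like ester

A few compounds are considered here, and "the series" means these few. Any claim that something is new, unique, unknown or untested is made for them only; others in the source may bear on it.

Three related compounds have been tested in a functional assay on cells (+SA cell, Mus musculus) for cytotoxicity, read by MTT assay, with a stated time of 24 h; on this read-out higher numbers stand for weaker inhibition and lower numbers for stronger inhibition. Compound 1, `CC(C)=CCC/C(C)=C/CC/C(C)=C/CC[C@]1(C)CCc2c(C)c(OC(=O)c3ccc(C(=O)O)cc3C(=O)O)c(C)c(C)c2O1`, gives 1500 nM in this assay. Compound 2, `CC(C)=CCC/C(C)=C/CC/C(C)=C/CC[C@]1(C)CCc2cc(OC(=O)c3ccc(C(=O)O)cc3C(=O)O)c(C)c(C)c2O1`, gives 620 nM. The two differ by one change, (hydrogen in place of methyl on an aromatic carbon), and this produced a 2.4-fold lower number from compound 1 to compound 2 (0.38 log units; beyond the scatter). Compound 3, `CC(C)=CCC/C(C)=C/CC/C(C)=C/CC[C@]1(C)CCc2cc(OC(=O)c3cc(C(=O)O)ccc3C(=O)O)c(C)c(C)c2O1`, gives 1440 nM; it differs from compound 2 by a 2.3-fold higher number from compound 2 to compound 3 (0.37 log units; beyond the scatter). The difference between the core of compound 1 and the core of compound 3 is not broken down here.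

Compound 4, `CC(C)=CCC/C(C)=C/CC/C(C)=C/CC[C@]1(C)CCc2cc(OC(=O)c3cc(C(=O)O)ccc3C(=O)O)cc(C)c2O1`, has not yet been measured. It differs from compound 3 by hydrogen in place of methyl on an aromatic carbon. Within the data shown here, this is the same kind of change as the one from compound 1 to compound 2, but not the same: in the earlier pair the carbon was ortho to a fused ring, meta to a methyl group and para to a methyl group, whereas in compound 3 the carbon is ortho to a methyl group and para to a fused ring; both sit ortho to a large group and meta to a fused ring.

Among the measured compounds shown here, because the earlier change gave a 2.4-fold lower number from compound 1 to compound 2 (0.38 log units; beyond the scatter), a step of similar direction and size is expected here, though the surroundings of the carbon differ and only one prior example exists. The expected step from compound 3 to compound 4 is a 2.1-fold lower number from compound 3 to compound 4 (0.31 log units; beyond the scatter). Compound 4 is therefore estimated to give 700 nM in this assay, with a likely range from 300 nM to 1600 nM.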

Compound 4, half-maximal inhibitory concentration: 1500 nM
Beside the measured number, compound 4's estimate is 2.1-fold (0.33 log units) below it; the measured number falls inside the stated range.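

In this assay, putting hydrogen in place of the methyl on the core of compound 3 gave a 1.0-fold higher number from compound 3 to compound 4 (0.02 log units; within the scatter), so this step, unlike the earlier one, does not stand out from ordinary repeat-to-repeat variation. Set side by side, however, the two steps cannot be told apart: the same change on two cores in this assay, a 2.4-fold lower number (0.38 log units; beyond the scatter) from compound 1 to compound 2 and a 1.0-fold higher number (0.02 log units; within the scatter) from compound 3 to compound 4, 2.5-fold (0.40 log units) apart, within the scatter of two such steps. The result therefore does not show that the change behaves differently on the two cores, nor does it show that the change carries over reliably; one step is clear and the other is not, the methyl leaves a differently surrounded ring carbon in each pair, and two pairs are too few to settle the matter.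

The compounds shown leave open how the core of compound 4 would respond with the acid arrangement of compound 2, which would test whether that arrangement and the loss of this methyl act independently of each other. They also leave open what an ethyl group, a methoxy group or a chlorine atom would do at this ring carbon, and whether an amide in place of the ester linkage would alter the picture.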